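Carbamate side-chain variation on the fluorobenzyl-pyrazolopyridine series

A few compounds are considered here, and "the series" means these few. Any claim that something is new, unique, unknown or untested is made for them only; others in the source may bear on it.

Compound 1 `CCN(C(=O)OC)c1c(N)nc(-c2nn(Cc3ccccc3F)c3ncccc23)nc1N` and compound 2 `COC(=O)N(CCO)c1c(N)nc(-c2nn(Cc3ccccc3F)c3ncccc23)nc1N` share the core and differ only in the chain on the amide-type nitrogen. In an assay on cells for activation of Guanylate cyclase soluble subunit alpha-1 (Rattus norvegicus), read by cGMP accumulation and immunoassay, with a stated time of 10 min (on this read-out lower numbers stand for an effect already at smaller amounts and higher numbers for an effect only at larger amounts of compound), compound 1 gives 0.2 uM and compound 2 gives 0.3 uM; the step of a 1.5-fold higher number from compound 1 to compound 2 (0.18 log units; within the scatter) lies within the scatter, so compound 2 stands at the higher of two numbers without any ordering between the two being claimed.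

Compound 3 `COC(=O)N(Cc1ccccc1F)c1c(N)nc(-c2nn(Cc3ccccc3F)c3ncccc23)nc1N` arises from compound 2 by the change (2-fluorophenyl in place of hydroxymethyl on a saturated chain carbon bound to an amide-type nitrogen). Among the compounds with values here, the only measured step, from compound 1 to compound 2, swaps hydrogen for hydroxy two bonds along the chain and moves the number only within the scatter; no measured step replaces a small chain end with an aromatic ring, so the size of this step is not anchored by the data. The expectation for compound 3 in this assay is therefore centred near compound 2 with a broad range, the expected step being a 1.7-fold higher number from compound 2 to compound 3 (0.22 log units; within the scatter). The estimated value for compound 3 is 0.5 uM, expected to fall between 0.1 uM and 3 uM.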

Compound 3, minimum effective concentration: 0.1 uM
Compound 3: the middle estimate sits 5.0-fold (0.70 log units) above what was measured; the measured number falls inside the stated range.
By their numbers in this assay, from the lowest: compounds 3, 1 and 2 (each within the scatter of the next, the first and the last beyond it).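

In this assay, within the data shown here, a 2-fluorobenzyl chain on the amide-type nitrogen gives a 3.0-fold lower number from compound 2 to compound 3 (0.48 log units; beyond the scatter), the first step to lie beyond the scatter. Against compound 1, the same position gives a 2.0-fold lower number from compound 1 to compound 3 (0.30 log units; within the scatter), so a six-membered aromatic ring on this saturated chain carbon is tolerated, and the separation appears only against the 2-hydroxyethyl chain of compound 2. No supporting data bear on the origin of this step.

Still open, going by these compounds, is what the fluorine adds to the ring, which a plain benzyl chain would test. Also open, on these data alone, is whether a longer chain ending in 2-fluorophenyl, or an amine or a carboxylic acid at the chain end, would stay at this level.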